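The source may report more compounds than this note shows. Statements on the series, on what has been measured and on what is new or still open speak of the compounds shown alone.

Measured in a functional assay on A-375 cells (Homo sapiens) for antiproliferative activity; a lower number here means a stronger inhibitor, a higher number a weaker inhibitor:
- compound 1 `O=C(Nc1ccc(-c2cscn2)cc1)C1CCCN(Cc2ccc(F)c(F)c2)C1`: 880 nM
- compound 2 `O=C(Nc1ccc(-c2cscn2)cc1)C1CCCN(C(=O)c2ccc(F)c(F)c2)C1`: > 20000 nM

Compound 2 stands at > 20000 nM, which is a limit of the assay. Going by the values given here, compound 1 therefore holds the only actual number in this assay so far.

Next is compound 3 `O=C(Nc1ccc(-c2cscn2)cc1)[C@@H]1CCCN(Cc2ccc(F)c(F)c2)C1`. The change from compound 1 is the two compounds have the same atoms and bonds; at least one stereo element is drawn with a configuration in one of them and without one in the other: 1 of 1 stereo elements differ; a stereocentre at a saturated ring carbon is drawn without a configuration in compound 1 and R in compound 3.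

Among the compounds with values here, the one measured step, an at least 22-fold higher number from compound 1 to compound 2 (1.35 log units; beyond the scatter), sits on the amine nitrogen in the ring and leaves the stereocentre untouched. It shows that this series can move sharply, but it gives no direct guide to the effect of configuration. Within the data shown here, no measured pair isolates that effect.

With the atoms and bonds unchanged, the expectation rests on compound 1 at 880 nM, with no clear direction. The expected change is a 1.3-fold lower number from compound 1 to compound 3 (0.10 log units; within the scatter), which would not clearly exceed the scatter. The estimate for compound 3 is 700 nM, with an expected range of 250 nM to 3000 nM.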

Compound 3, half-maximal inhibitory concentration: 6000 nM
Beside the measured number, compound 3's estimate is 8.6-fold (0.93 log units) below it; the whole stated range lies below it.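

In this assay, the stereocentre at the saturated ring carbon now shows a measured effect of its own: a 6.8-fold higher number from compound 1 to compound 3 (0.83 log units; beyond the scatter), with no atom or bond changed. Going by these compounds alone, the earlier step concerned only the group on the amine nitrogen, so this is the first sign that the series also responds to how this centre is drawn, and the R drawing does not match the number of compound 1. The comparison rests on a defined form against an undefined drawing, not on two defined forms: the fact that one of compounds 1 and 3 is drawn with a defined configuration and the other without, at the place where they differ

From the compounds shown here alone, what compound 1 holds at this centre remains open, as does the reading of the S configuration in this assay. Also open, going by these compounds, is how a pyridinylmethyl group in place of 3,4-difluorobenzyl on the amine nitrogen would read with the R configuration.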